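The compounds below may be only part of what the source reports. "The series", "measured", "known", "first", "only" and "open" are said of these compounds alone.

Three compounds built on one shared core were tested in an assay on LX2 cells for inhibition of COL1A1 promoter (Homo sapiens), read by a luciferase reporter, with a stated time of 24 h, tested at 50 uM; a higher number here means a stronger effect of the compound at the concentration tested, a lower number a weaker effect. Compound 1, `Cc1cc(-n2cc(C(=O)Nc3cc(F)cc(F)c3)c(=O)c3ccc(N(C)C)nc32)ccc1OCCCCCCC[N+]1(C)CCCCC1`, gives 54.4% in this assay. Compound 2, `Cc1ccc(-n2cc(C(=O)Nc3cc(F)cc(F)c3)c(=O)c3ccc(N(C)C)nc32)cc1OCCCCCCC[N+]1(C)CCCCC1`, is made of the same atoms joined differently; the difference between the two cores is not broken down here. In this assay compound 2 gives 45.1%, the lowest of the three numbers, though its distance to each of the others lies within the scatter. Compound 3, `Cc1cc(-n2cc(C(=O)Nc3cc(F)cc(F)c3)c(=O)c3ccc(N(C)C)nc32)ccc1OCCCCCCC[n+]1ccccc1`, differs from compound 1 by one change: a group of 6 heavy atoms (5 carbon, 1 nitrogen; one six-membered aromatic ring with 1 hetero atom) in place of a group of 7 heavy atoms (6 carbon, 1 nitrogen; one six-membered non-aromatic ring with 1 hetero atom), on a saturated chain carbon, seven bonds along the chain from an oxygen on an aromatic ring. In this assay compound 3 gives 55%. That change made a number 0.6 percentage points higher from compound 1 to compound 3 (within the scatter), so the charged ring at the end of the chain was swapped without a visible effect.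

Compound 4, `Cc1ccc(-n2cc(C(=O)Nc3cc(F)cc(F)c3)c(=O)c3ccc(N(C)C)nc32)cc1OCCCCCCC[n+]1ccccc1`, has not yet been measured. It stands to compound 2 exactly as compound 3 stands to compound 1, carrying the change (a group of 6 heavy atoms (5 carbon, 1 nitrogen; one six-membered aromatic ring with 1 hetero atom) in place of a group of 7 heavy atoms (6 carbon, 1 nitrogen; one six-membered non-aromatic ring with 1 hetero atom), on a saturated chain carbon, seven bonds along the chain from an oxygen on an aromatic ring). The change occurs twice among these compounds, and its one measured instance is the step above. The expectation for compound 4 rests on that single instance alone, since nothing else about the chain end has been varied. The step is therefore expected to be a number 0.9 percentage points higher from compound 2 to compound 4 (within the scatter), essentially flat like the measured one. In this assay compound 4 is expected to give about 46%, with a likely range from 35% to 57%.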

Compound 4, a percentage reported as inhibition, at one concentration (the size of the read-out at that concentration, not a potency): 22.2%
For compound 4 the middle estimate is 23.8 percentage points above the measured one; measured number outside the range, below it.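

In this assay, putting the six-membered aromatic ring in place of the six-membered non-aromatic ring at the end of the chain gave a number 22.9 percentage points lower from compound 2 to compound 4 (beyond the scatter). The same swap on the core of compound 1 had made no visible difference, so on these two cores it does not carry over as a fixed step: the same change on two cores in this assay, a number 0.6 percentage points higher (within the scatter) from compound 1 to compound 3 and a number 22.9 percentage points lower (beyond the scatter) from compound 2 to compound 4, 23.5 percentage points apart, beyond the scatter of two such steps

This shows that, in this small set, the outcome of the swap depends on which of the two cores carries it, so a step measured on one core is a poor guide to the other; it does not show why the two cores part ways, and with a single pair on each core it gives no general rule for the series.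

Still open, as far as these compounds go, is whether other chain ends, such as a morpholine ring, a trimethylammonium group or an uncharged tertiary amine, would also separate the two cores, and whether a shorter or longer chain would widen or close the gap. From the compounds shown here alone, each number is also a read-out at one concentration rather than a potency, so how the compounds compare across a range of concentrations remains open too.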